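The source may hold more compounds than are shown below. What is called first, only, known or untested is meant among the compounds shown, and "the series" means these compounds.

Of the compounds shown here, three sharing one core have been measured in a functional assay on HEK293 cells for agonist activity at Glucose-dependent insulinotropic receptor (Homo sapiens), read by reporter gene assay and cAMP accumulation, with a stated time of 6 h; on this read-out lower numbers stand for an effect already at smaller amounts and higher numbers for an effect only at larger amounts of compound. Compound 1 `CN(C)C(=O)C1CCN(c2nc(-c3cc(F)c(Cl)cc3F)nc3c2CS(=O)(=O)C3)CC1` gives 350 nM. Compound 2 `O=C(O)C1CCN(c2nc(-c3cc(F)c(Cl)cc3F)nc3c2CS(=O)(=O)C3)CC1` gives 560 nM, and the step between them is a 1.6-fold higher number from compound 1 to compound 2 (0.20 log units; within the scatter). Compound 3 `NC(=O)CCC1CCN(c2nc(-c3cc(F)c(Cl)cc3F)nc3c2CS(=O)(=O)C3)CC1` gives 18 nM, the lowest number of the three: a 19-fold lower number from compound 1 to compound 3 (1.29 log units; beyond the scatter) and a 31-fold lower number from compound 2 to compound 3 (1.49 log units; beyond the scatter).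

Compound 4 `CNC(=O)C1CCN(c2nc(-c3cc(F)c(Cl)cc3F)nc3c2CS(=O)(=O)C3)CC1` has not yet been measured. It differs from compound 3 in one place: methylcarbamoyl in place of 2-carbamoylethyl on a saturated ring carbon. The measured step that bears on this change is a 19-fold lower number from compound 1 to compound 3 (1.29 log units; beyond the scatter), as compound 1 carries a dimethylcarbamoyl group directly on the saturated ring carbon, just as compound 4 carries a methylcarbamoyl group there. In addition, a 1.6-fold higher number from compound 1 to compound 2 (0.20 log units; within the scatter) shows that two different short groups on that carbon gave similar numbers. Compound 4 is therefore expected to show a step of a 10-fold higher number from compound 3 to compound 4 (1.00 log units; beyond the scatter) toward higher numbers, beyond the scatter. In this assay compound 4 is estimated at 180 nM, within a range of 45 nM to 700 nM.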

Compound 4, effective concentration (reported as EC, without a stated level of effect): 51 nM
The estimate for compound 4 lay 3.5-fold (0.55 log units) above the measured number; the range from low to high includes it.
By their numbers in this assay, from the lowest: compound 3; then compound 4; then compounds 1 and 2 (each within the scatter of the next).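

In this assay hydrogen in place of methyl on the amide-type nitrogen gives a 6.9-fold lower number from compound 1 to compound 4 (0.84 log units; beyond the scatter) and shows that this position responds to a small change within a short group, which the earlier pair of short groups had not shown. Methylamino in place of hydroxy on the carbonyl carbon gives an 11-fold lower number from compound 2 to compound 4 (1.04 log units; beyond the scatter) and so separates two short groups on the saturated ring carbon by more than the scatter. Compound 3 keeps the lowest number, and methylcarbamoyl in place of its 2-carbamoylethyl gives a 2.8-fold higher number from compound 3 to compound 4 (0.45 log units; beyond the scatter) as a modest step. Nothing available here gives a reason for these steps.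

The compounds shown leave open whether a primary carboxamide on the same ring carbon would continue the change seen on losing the methyl. They also leave open whether carbamoylmethyl or a chain longer than 2-carbamoylethyl would give a number lower than that of compound 3.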